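This account rests on a few compounds, and the source may have more. Where it says the series, first, only, none or still open, it means among the compounds named here.

Measured compounds:
compound 1 `ClCc1ccc(Cn2cnc3nc(Cl)nc(Cl)c32)cc1`, 6020 nM
compound 2 `ClCc1ccccc1Cn1cnc2ncnc(Cl)c21`, 25100 nM
compound 3 `ClCc1ccccc1Cn1cnc2nc(Cl)nc(Cl)c21`, 3230 nM

In a functional assay on MDA-MB-231 cells (Homo sapiens) for cytotoxicity, read by sulforhodamine B assay, with a stated time of 48 h (on this read-out lower numbers stand for higher toxicity in this test and higher numbers for lower toxicity in this test), compound 3 gives 3230 nM and compound 1 gives 6020 nM; these two values lie within the usual scatter of each other. Compound 2 gives 25100 nM. Compound 2 differs from compound 3 by hydrogen in place of chloro on an aromatic carbon, and this change produced a 7.8-fold higher number from compound 3 to compound 2 (0.89 log units; beyond the scatter). Compound 4 `ClCc1ccc(Cn2cnc3ncnc(Cl)c32)cc1` has not yet been measured; it differs from compound 1 by hydrogen in place of chloro on an aromatic carbon, the same change at the same place. How the core of compound 1 differs from the core of compound 3 is not broken down here. Compound 4 is expected to show a 7.5-fold higher number from compound 1 to compound 4 (0.87 log units; beyond the scatter), an expectation resting on the measured step of a 7.8-fold higher number from compound 3 to compound 2 (0.89 log units; beyond the scatter). Compound 4 is therefore estimated at 45000 nM, with a likely range from 18000 nM to 120000 nM.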

Compound 4, concentration lethal to 50% of the cells: 6300 nM
Compound 4: middle estimate off by 7.1-fold (0.85 log units), on the high side, and the stated range ends above it.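

In this assay, hydrogen in place of the chloro group between two ring nitrogen atoms did not give the same result on the two cores: the same change on two cores in this assay, a 7.8-fold higher number (0.89 log units; beyond the scatter) from compound 3 to compound 2 and a 1.0-fold higher number (0.02 log units; within the scatter) from compound 1 to compound 4, 7.4-fold (0.87 log units) apart, beyond the scatter of two such steps. On the core of compound 1, the change gives a 1.0-fold higher number from compound 1 to compound 4 (0.02 log units; within the scatter), so the larger step seen on the other core cannot be assumed to carry over to every core in this series. These two pairs show that the size of the step differs with the core, but they do not show which difference between the cores is responsible.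

The compounds shown leave open how an amine or a methoxy group at that same place would read on either core. They also leave open what a hydroxymethyl group in place of the chloromethyl group would do.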